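Hydrogen in Place of Pentyl on Selenium: Cytotoxicity Outlook

This account rests on a few compounds, and the source may have more. Where it says the series, first, only, none or still open, it means among the compounds named here.

Measured compounds:
Compound 1, `COc1ccc(CNc2nc([SeH])nc3ccccc23)cc1`, in a functional assay on MCF7 cells (Homo sapiens) for cytotoxicity, read by MTT assay, with a stated time of 72 h; a higher number here means that more compound is tolerated, a lower number that less compound is tolerated: > 100000 nM
Compound 2, `CCCCC[Se]c1nc(NCc2ccc(SC)cc2)c2ccccc2n1`, in this assay: 95300 nM

Compound 1 reaches only a limit of the assay, not a number. Compound 2 stands as the only numerical value among the two shown; the other value is a limit, as described by the limit of > 100000 nM in this assay, at which 1 of the 2 values shown sits.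

Compound 3, `CSc1ccc(CNc2nc([SeH])nc3ccccc23)cc1`, is not yet measured. It differs from compound 2 in one place: hydrogen in place of pentyl on a selenium. Among the measured compounds shown here, no pair of measured compounds differing in a single place exists here, so the size of this step cannot be read from the data. Compound 3 carries the same selenium-bound hydrogen as compound 1, and compound 1 sits at the limit; compound 2 lies close to that limit as well. The expectation for compound 3 is therefore a change from compound 2 that stays within the scatter, a 1.2-fold higher number from compound 2 to compound 3 (0.06 log units; within the scatter), with a real chance that only a limit is reported. Compound 3 is estimated at 110000 nM, within a range of 50000 nM to 250000 nM.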

Compound 3, concentration lethal to 50% of the cells: > 100000 nM
Compound 3: only a limit was reported (the forecaster's own chance of this, stated with the estimate: 55%); the middle value lies beyond the limit too.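

In this assay compound 3 gives > 100000 nM, which is a limit of the assay. With hydrogen in place of pentyl on the selenium, the data now give an at least 1.0-fold higher number from compound 2 to compound 3 (0.02 log units; that floor lies within the scatter). Among the compounds shown here, this is the first reading of this change at this position, but it fixes only a floor, so the pentyl group can be credited with no real effect on the number, and a larger effect cannot be excluded either. The step from methoxy to methylsulfanyl on an aromatic carbon, between the two compounds that carry the selenium-bound hydrogen, cannot be read, and most of the values now sit at one end of the scale: the limit of > 100000 nM in this assay, at which 2 of the 3 values shown sit.

The compounds shown leave open how far the true value of compound 3 lies from that of compound 2, and whether any group on the selenium can shift the number clearly. A longer chain or a benzyl group on the selenium in place of pentyl would show whether the number can drop well below that of compound 2, at 95300 nM.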